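Notes on a 2,4-dichlorophenyl for thiophen-2-yl exchange

This account rests on a few compounds, and the source may have more. Where it says the series, first, only, none or still open, it means among the compounds named here.

Measured so far:
compound 1 `COC(=O)c1cc(-c2csc(N/N=C/c3cccs3)n2)ccc1OCc1ccccc1` gives 87.6%
compound 2 `Clc1ccc(-c2csc(N/N=C/c3cccs3)n2)cc1` gives 86%
compound 3 `Fc1ccc(-c2csc(N/N=C/c3ccc(Cl)cc3Cl)n2)cc1` gives 94%

All three numbers come from a functional assay, read by spectrophotometry, with a stated time of 15 min, tested at 80 ug/mL; a higher number here means a stronger effect of the compound at the concentration tested, a lower number a weaker effect. Compound 1 stands second highest of the three, but compound 2 and compound 3 both lie within the scatter of it, so the three values cannot be ordered and no one of them can be called the strongest.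

Compound 4 `COC(=O)c1cc(-c2csc(N/N=C/c3ccc(Cl)cc3Cl)n2)ccc1OCc1ccccc1` has not been measured. It differs from compound 1 in one place: 2,4-dichlorophenyl in place of thiophen-2-yl on a carbon with a double bond to nitrogen. Within the data shown here, no pair of measured compounds isolates this change, but compound 3 carries the same 2,4-dichlorophenyl and gives 94%, while compound 2 carries thiophen-2-yl and gives 86%; these two values sit within the scatter of each other.

On that basis the step from compound 1 to compound 4 is expected to stay within the scatter, with at most a small upward lean: the estimated step is a number 2.4 percentage points higher from compound 1 to compound 4 (within the scatter). For compound 4 the expected value in this assay is 90%, with a range of 80% to 97%.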

Compound 4, a percentage reported as inhibition, at one concentration (the size of the read-out at that concentration, not a potency): 71.8%
Estimate against measurement, compound 4: 18.2 percentage points above, and the stated range ends above it.
By their numbers in this assay, from the lowest: compound 4; then compounds 2, 1 and 3 (each within the scatter of the next).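

In this assay, among these compounds, the exchange of thiophen-2-yl for 2,4-dichlorophenyl on a carbon with a double bond to nitrogen gives a number 15.8 percentage points lower from compound 1 to compound 4 (beyond the scatter), the first change read at a single place, and it shows that this position is not indifferent to the group it carries on the core of compound 1. Compound 3 also carries 2,4-dichlorophenyl on a different aryl background, so the drop can be stated only for the pair of compound 1 and compound 4. Nothing available explains the drop.

From the compounds shown here alone, whether the loss follows one chlorine or both remains open, and plain phenyl or 4-chlorophenyl at this place would separate the two. Also open, going by these compounds, is whether furan-2-yl would hold the read-out as thiophen-2-yl does, and whether the same exchange on the core of compound 2 gives a step of similar size.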